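The source may report more compounds than this note shows. Statements on the series, on what has been measured and on what is new or still open speak of the compounds shown alone.

Working notes on the series

The first member, compound 1 `Oc1cccc2cc(-c3ccccc3)ccc12`, carries a hydroxyl on the shared core and an unsubstituted phenyl. In an assay for binding affinity to 17-beta-hydroxysteroid dehydrogenase type 1 (Homo sapiens), with a stated time of 20 min, tested at 1 uM (on this read-out higher numbers stand for more inhibition at the one concentration tested (going by the name of the read-out) and lower numbers for less inhibition), compound 1 gives < 10%, which is a limit of the assay rather than a number. Compound 2 `CS(=O)(=O)Nc1cccc(-c2ccc3c(O)cccc3c2)c1` adds a methanesulfonamido group to that phenyl. In this assay, within the data shown here, compound 2 gives 19%, the only actual number among the two values at hand. Among the measured compounds shown here, the one measured step, a number at least 9 percentage points higher from compound 1 to compound 2 (that floor lies within the scatter), rests on a floor set by the limit of < 10% in this assay, at which 1 of the 2 values shown sits, so its true size is uncertain and the floor sits within the scatter.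

The next member, compound 3 `CNC(=O)c1cccc(-c2ccc3c(O)cccc3c2)c1`, differs from compound 2 by methylcarbamoyl in place of methanesulfonamido on an aromatic carbon. For the measured compounds named here, no measured step changes a group of this kind on the phenyl, so the only guide is that compound 2 itself sits low in this assay and that the single step from compound 1 to compound 2 was small. For compound 3 the step of a number 4 percentage points lower from compound 2 to compound 3 (within the scatter) is therefore expected to stay within the scatter. Compound 3 is estimated at 15% in this assay, with a range from 4% to 30%.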

Compound 3, a percentage reported as inhibition, at one concentration (the size of the read-out at that concentration, not a potency): < 10%
Compound 3 gave a limit, no number (the forecaster's own chance of this, stated with the estimate: 30%); at least 5 percentage points between middle value and limit.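

At this position, on an aromatic carbon meta to a large group, the exchange of methanesulfonamido for methylcarbamoyl gives a number at least 9 percentage points lower from compound 2 to compound 3 (that floor lies within the scatter) in this assay. With compound 3 reported as a limit, two different groups have now been read at this place on the phenyl, and neither reading stands clear of the scatter from the unsubstituted compound 1, so the series offers no firm sign that a substituent here raises inhibition at the one concentration tested. The true size of the step to compound 3 stays uncertain, and the step from compound 1 to compound 3 cannot be read at all, because both ends of it are limits, which also leaves the ranking of the two groups open: the limit of < 10% in this assay, at which 2 of the 3 values shown sit.

The compounds shown leave open whether any group on this carbon can lift the reading clearly above the limit, for instance a carboxylic acid, an amine or a longer chain in place of methylcarbamoyl. They also leave open whether the same groups would read differently on another carbon of the phenyl, or whether the hydroxyl on the shared core matters, as a methoxy group there would test.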